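The source may hold more compounds than are shown below. What is called first, only, known or untested is meant among the compounds shown, and "the series" means these compounds.

Compound 1 `Cc1cc(O)c(C(C)C)cc1-c1cc(-c2ccccc2)c(C#N)c(=O)[nH]1` is the weaker of the two measured compounds in a functional assay for inhibition, tested at 60 ug/mL (on this read-out lower numbers stand for a weaker effect and higher numbers for a stronger effect at the one concentration tested), where compound 1 gives 34%. Among the measured compounds shown here, its only measured neighbour, compound 2 `COc1ccc(-c2cc(-c3cc(C(C)C)c(O)cc3C)[nH]c(=O)c2C#N)c(OC)c1`, gives 48.5% in this assay; the single measured step, a number 14.5 percentage points higher from compound 1 to compound 2 (beyond the scatter), consists of a 2,4-dimethoxyphenyl in place of phenyl on an aromatic carbon. Compound 3 `COc1ccc(-c2cc(-c3cc(C(C)C)c(O)cc3C)[nH]c(=O)c2C#N)cc1` has not yet been tested. It differs from compound 1 by methoxy in place of hydrogen on an aromatic carbon, which is part of the change that separates compound 1 from compound 2. The step from compound 1 to compound 2 is therefore the one that bears on the question, and it was modest but beyond the scatter. On that basis compound 3 is expected to show a small rise, a number 8 percentage points higher from compound 1 to compound 3 (within the scatter), in this assay. The estimate for compound 3 is 42%, with a range from 30% to 55%.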

Compound 3, a percentage reported as inhibition, at one concentration (the size of the read-out at that concentration, not a potency): 43%
Beside the measured number, compound 3's estimate is 1 percentage points below it; measured number inside the range.
By their numbers in this assay, from the lowest: compounds 1, 3 and 2 (each within the scatter of the next, the first and the last beyond it).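

Read alone in this assay, the change from phenyl to 4-methoxyphenyl, para to a large group, stays within the scatter (a number 9 percentage points higher from compound 1 to compound 3 (within the scatter)), and so does taking away the other methoxy of the 2,4-dimethoxyphenyl group (a number 5.5 percentage points lower from compound 2 to compound 3 (within the scatter)). Neither single methoxy step therefore separates its pair, whereas the two methoxy groups together do (a number 14.5 percentage points higher from compound 1 to compound 2 (beyond the scatter)), so compound 3 cannot be told apart from either neighbour on this read-out. No measurement shown here offers an explanation for this result.

From the compounds shown here alone, what a methoxy would give at the other substituted carbon of compound 2 without the 4-methoxy remains open. So does whether an amine, a carboxylic acid or a longer chain such as ethoxy in place of the methoxy of compound 3 would read differently.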